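Replacing 3,4-dimethoxyphenyl with 2-methoxyphenyl in compound 1

The source may report more compounds than this note shows. Statements on the series, on what has been measured and on what is new or still open speak of the compounds shown alone.

Compound 1 (`COc1ccc(/C=C/C(=O)/C=C/c2ccc(OCc3cn(CCCCOc4cc(=O)oc5ccccc45)nn3)c(OC)c2)cc1OC`): 59%
Compound 2 (`COc1cc(/C=C/C(=O)/C=C/c2cccs2)ccc1OCc1cn(CCCCCOc2cc(=O)oc3ccccc23)nn1`): 34%

In a functional assay on THP-1 cells (Homo sapiens) for inhibition, read by sulforhodamine B assay, with a stated time of 48 h, tested at 50 uM (a higher number here means more inhibition of growth at the concentration tested, a lower number less inhibition of growth), compound 1 stands highest of the two measured compounds with 59% as its value. Compound 2 gives 34% in the same test, a gap beyond the scatter. These two compounds differ in more than one place, so their gap cannot be assigned to any single change.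

Compound 3 (`COc1ccccc1/C=C/C(=O)/C=C/c1ccc(OCc2cn(CCCCOc3cc(=O)oc4ccccc34)nn2)c(OC)c1`) keeps the rest of compound 1 and changes one group (2-methoxyphenyl in place of 3,4-dimethoxyphenyl on a double-bonded chain carbon bound to a double-bonded chain carbon). Here 2-methoxyphenyl stands in place of 3,4-dimethoxyphenyl on a double-bonded chain carbon bound to a double-bonded chain carbon.

Going by the values given here, no measured pair shows the size of this change directly. The expectation therefore starts from compound 1 with its 59% as the anchor, and a small downward step in this assay is expected, not beyond the scatter. The expected move is a number 9 percentage points lower from compound 1 to compound 3 (within the scatter) on this estimate. Compound 3 is expected at 50% with an estimated range from 30% to 70% (an estimate only).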

Compound 3, percent growth inhibition at one concentration: 40%
Compound 3: middle estimate off by 10 percentage points, on the high side, and the stated range covers the measured number.
By their numbers in this assay, from the lowest: compounds 2 and 3 (each within the scatter of the next); then compound 1.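

In this assay, putting 2-methoxyphenyl in place of 3,4-dimethoxyphenyl on a double-bonded chain carbon bound to a double-bonded chain carbon gives a number 19 percentage points lower from compound 1 to compound 3 (beyond the scatter). Going by these compounds alone, this is the first effect that can be tied to a single place, as compound 1 and compound 2 differ in more than one, and it shows that growth inhibition here responds to the aryl group at this position while the rest of compound 1 stays fixed. The entering group has fewer heavy atoms and fewer hydrogen-bond acceptors than the one it replaces, but nothing available explains the lower number for compound 3.

This single step changes both how many methoxy groups the ring carries and where they stand, so the compounds shown cannot separate those two changes. They also leave open how this position would respond to an unsubstituted phenyl, or to a ring bearing a hydroxyl or an amine in place of the methoxy groups.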